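This account rests on a few compounds, and the source may have more. Where it says the series, first, only, none or still open, it means among the compounds named here.

Compound 3 `Cc1ccc(C(=O)O)cc1OCCCCOc1ccc(C(=O)CC2CCCC2)c(O)c1C` in an assay on HEK293 cells for positive allosteric modulation of metabotropic glutamate receptor 2 (Rattus norvegicus), read by thallium flux, with a stated time of 2.5 min (a lower number here means a smaller maximal response, a higher number a larger maximal response), gives 67.5%, the second highest of the three numbers. Compound 1 `Cc1c(OCCCCOc2ccc(C(=O)O)cc2F)ccc(C(=O)CC2CCCC2)c1O` gives 83.8% and compound 2 `Cc1c(OCCCCOc2ccc(F)c(C(=O)O)c2)ccc(C(=O)CC2CCCC2)c1C` gives 14.6%, so compound 3 sits nearer compound 1 than compound 2. Among the compounds with values here, the one measured step on this core, a number 16.3 percentage points lower from compound 1 to compound 3 (beyond the scatter), changes only the aryl group on the oxygen on a saturated carbon.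

Compound 4 `Cc1c(OCCCCOc2ccc(F)c(C(=O)O)c2)ccc(C(=O)CC2CCCC2)c1O` differs from compound 3 in the same place: 3-carboxy-4-fluorophenyl in place of 5-carboxy-2-methylphenyl on an oxygen on a saturated carbon. Within the data shown here, no measured step pairs compound 3 with this aryl group. Among the measured compounds shown here, compound 2 carries 3-carboxy-4-fluorophenyl on a different core and gives the lowest number in this assay, but no step links compound 2 to compound 4, so the two values can only be set beside each other. The expectation is therefore a downward step, a number 22.5 percentage points lower from compound 3 to compound 4 (beyond the scatter), with wide uncertainty. For compound 4 the estimate in this assay is 45%, in the range 15% to 80%.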

Compound 4, largest response reached (reported as percent of maximum), in percent of the reference or control that the assay uses: 81%
Beside the measured number, compound 4's estimate is 36 percentage points below it; measured number above the stated range.
By their numbers in this assay, from the lowest: compound 2; then compound 3; then compounds 4 and 1 (each within the scatter of the next).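

With 3-carboxy-4-fluorophenyl held fixed, hydroxy in place of methyl on an aromatic carbon gives a number 66.4 percentage points higher from compound 2 to compound 4 (beyond the scatter) in this assay, so the low response of compound 2 belongs to the methyl and not to this aryl group. On the oxygen on a saturated carbon, 3-carboxy-4-fluorophenyl in place of 4-carboxy-2-fluorophenyl gives a number 2.8 percentage points lower from compound 1 to compound 4 (within the scatter) and the two aryl groups cannot be told apart. In place of 5-carboxy-2-methylphenyl, the same group gives a number 13.5 percentage points higher from compound 3 to compound 4 (beyond the scatter) and this reverses the downward reading of 5-carboxy-2-methylphenyl as the better partner. Nothing shown explains any of these steps.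

Going by these compounds, whether the methyl penalty also holds with 4-carboxy-2-fluorophenyl or 5-carboxy-2-methylphenyl stays open. Also open, on these data alone, is how a methoxy or an amine in place of the hydroxy, or a longer chain between the two oxygens, would change the response.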